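Swapping the Azole Arm on a Shared Sulfonyl Core

The compounds below may be only part of what the source reports. "The series", "measured", "known", "first", "only" and "open" are said of these compounds alone.

The measured compounds and their values in a functional assay on HT-29 cells (Homo sapiens); on this read-out higher numbers stand for weaker inhibition of growth and lower numbers for stronger inhibition of growth: compound 1 `COc1cc(CSc2cc(Cl)c(-c3nnc(-c4ccc(Cl)cc4)s3)cc2S(=O)(=O)NC(=N)NO)cc(OC)c1OC` gives 6760 nM; compound 2 `COc1cc(CSc2cc(Cl)c(-c3nc(-c4ccccc4)no3)cc2S(=O)(=O)NC(=N)NO)cc(OC)c1OC` gives 7240 nM; compound 3 `COc1cc(CSc2cc(Cl)c(-c3nnc(-c4ccccc4)s3)cc2S(=O)(=O)NC(=N)NO)cc(OC)c1OC` gives 4170 nM.

Compound 3 sits at the lowest of the three numbers in this assay, yet its gaps to the others are small: a 1.6-fold lower number from compound 1 to compound 3 (0.21 log units; within the scatter) and a 1.7-fold lower number from compound 2 to compound 3 (0.24 log units; within the scatter), both within the scatter, so no order among the three can be claimed.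

Compound 4 `COc1cc(CSc2cc(Cl)c(-c3nc(-c4ccc(Cl)cc4)no3)cc2S(=O)(=O)NC(=N)NO)cc(OC)c1OC` is not yet measured. It differs from compound 3 by 3-(4-chlorophenyl)-1,2,4-oxadiazol-5-yl in place of 5-phenyl-1,3,4-thiadiazol-2-yl on an aromatic carbon, on an aromatic carbon of the shared core, ortho to a chloro group. Going by the values given here, two measured steps bear on this change. The exchange of the azole ring, phenyl kept, is seen in a 1.7-fold lower number from compound 2 to compound 3 (0.24 log units; within the scatter); the addition of chloro to the distal ring is seen in reverse in a 1.6-fold lower number from compound 1 to compound 3 (0.21 log units; within the scatter). Compound 4 combines both moves in the direction of higher numbers, and compound 1, which carries the chloro on the thiadiazole, already stands a little above compound 3. A modest rise, a 2.0-fold higher number from compound 3 to compound 4 (0.31 log units; beyond the scatter), is therefore expected, possibly just beyond the scatter but not far. Compound 4 is estimated at 8500 nM in this assay, within a range of 4200 nM to 17000 nM.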

Compound 4, concentration for 50% growth inhibition: 2950 nM
Estimate against measurement, compound 4: 2.9-fold (0.46 log units) above; the measured number lies below the stated range.
By their numbers in this assay, from the lowest: compounds 4, 3, 1 and 2 (each within the scatter of the next, the first and the last beyond it).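

On this position, the chloro on the distal phenyl ring now shows a step beyond the scatter in this assay: the oxadiazole arm gives a 2.5-fold lower number from compound 2 to compound 4 (0.39 log units; beyond the scatter) on gaining it. With the chloro kept on both arms, the azole exchange also reaches beyond the scatter, with a 2.3-fold lower number from compound 1 to compound 4 (0.36 log units; beyond the scatter) as the step, while a 1.4-fold lower number from compound 3 to compound 4 (0.15 log units; within the scatter) stays within it, so compound 3 and compound 4 cannot be ordered. The chloro therefore does not read the same on the two azoles, and the gap between its two steps exceeds the scatter: the same change on two cores in this assay, a 1.6-fold lower number (0.21 log units; within the scatter) from compound 1 to compound 3 and a 2.5-fold higher number (0.39 log units; beyond the scatter) from compound 4 to compound 2, 4.0-fold (0.60 log units) apart, beyond the scatter of two such steps.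

The compounds shown hold only hydrogen or chloro on the distal phenyl ring, so it remains open whether a fluoro group there would follow the chloro on either azole. From the compounds shown here alone, how an amine or a carboxylic acid at that place would read in this assay also remains open.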